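Quinoline thioether acids: cyanomethoxy replaced by trifluoromethyl

This account rests on a few compounds, and the source may have more. Where it says the series, first, only, none or still open, it means among the compounds named here.

Compound 1 `O=C(O)C1(Sc2ncnc3ccccc23)CCC1` and compound 2 `O=C1COc2cccc(SC3(C(=O)O)CCC3)c2N1` open the set. In an assay on HEK293 cells for inhibition of solute carrier family 22 member 12 (Homo sapiens), read by scintillation counting, with a stated time of 12 min (on this read-out lower numbers stand for stronger inhibition and higher numbers for weaker inhibition), compound 1 reports only the limit > 10000 nM. Compound 2 likewise reaches only the limit > 10000 nM. For the measured compounds named here, compound 3 `N#CCOc1ccc2nccc(SC3(C(=O)O)CCC3)c2c1` is the one member with a number in this assay, 680 nM; the other two values sit at the limit of > 10000 nM in this assay, at which 2 of the 3 values shown sit, so compound 3 stands alone as the only quantified point. Compound 4 `O=C(O)C1(Sc2ccnc3ccc(C(F)(F)F)cc23)CCC1` differs from compound 3 by trifluoromethyl in place of cyanomethoxy on an aromatic carbon. Going by the values given here, no measured pair in this set shows the effect of such a swap, so its size is unknown here. The expected step is a 1.2-fold higher number from compound 3 to compound 4 (0.07 log units; within the scatter), within the scatter rather than beyond it. Compound 4 is estimated at 800 nM, expected to lie between 250 nM and 3000 nM.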

Compound 4, half-maximal inhibitory concentration: 61.2 nM
Compound 4: the middle estimate sits 13-fold (1.12 log units) above what was measured; the whole stated range lies above it.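

Trifluoromethyl in place of cyanomethoxy on this aromatic carbon gives an 11-fold lower number from compound 3 to compound 4 (1.05 log units; beyond the scatter) in this assay, so the read-out responds strongly to the group at this position, which the earlier compounds could not show. The swap keeps the heavy-atom count of the group but removes the triple bond and the hydrogen-bond acceptors of cyanomethoxy. Nothing shown here gives a cause for the step.

Going by these compounds, it stays open whether the step follows from losing cyanomethoxy or from gaining trifluoromethyl; a methoxy group, a chlorine atom or plain hydrogen on this carbon would separate the two. On these data alone, whether the same swap carries over to other cores also stays open.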